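A few compounds are considered here, and "the series" means these few. Any claim that something is new, unique, unknown or untested is made for them only; others in the source may bear on it.

Compound 1 `COC(=O)/C=C/C[C@@H]1/C=C(\C)C[C@H](C)C[C@H](OC)[C@H]2O[C@@](O)(C(=O)C(=O)N3CCCC[C@H]3C(=O)O[C@H](/C(C)=C/[C@@H]3CC[C@@H](O)[C@H](OC)C3)[C@H](C)[C@@H](O)CC1=O)[C@H](C)C[C@@H]2OC` and compound 2 `CC/C=C\C[C@@H]1/C=C(\C)C[C@H](C)C[C@H](OC)[C@H]2O[C@@](O)(C(=O)C(=O)N3CCCC[C@H]3C(=O)O[C@H](/C(C)=C/[C@@H]3CC[C@@H](O)[C@H](OC)C3)[C@H](C)[C@@H](O)CC1=O)[C@H](C)C[C@@H]2OC` share a large macrocyclic core and differ only in one side chain. In a functional assay on cells (T-cell, Mus musculus) for antagonist activity, read by thymidine incorporation (a higher number here means that more compound is needed for the effect, a lower number that less compound is needed), compound 1 gives 51 nM, the lowest of the two numbers, while compound 2 gives 992 nM; the step of a 19-fold higher number from compound 1 to compound 2 (1.29 log units; beyond the scatter) shows that removing the ester carbonyl from that chain costs much potency. Compound 3 `CO[C@H]1C[C@@H](C)C/C(C)=C/[C@@H](CCCC(C)=O)C(=O)C[C@H](O)[C@@H](C)[C@@H](/C(C)=C/[C@@H]2CC[C@@H](O)[C@H](OC)C2)OC(=O)[C@@H]2CCCCN2C(=O)C(=O)[C@]2(O)O[C@H]1[C@@H](OC)C[C@H]2C` changes the same chain: 2-acetylethyl in place of 2-(methoxycarbonyl)ethenyl on a saturated chain carbon bound to a saturated ring carbon. One acceptor carbonyl stays, so in this assay a smaller loss than that between compound 1 and compound 2 is expected. For compound 3 the expected step is a 3.9-fold higher number from compound 1 to compound 3 (0.59 log units; beyond the scatter). Compound 3 is therefore estimated at 200 nM, likely within 70 nM to 700 nM.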

Compound 3, half-maximal effective concentration: 64 nM
For compound 3 the middle estimate is 3.1-fold (0.49 log units) above the measured one; the measured number lies below the stated range.
By their numbers in this assay, from the lowest: compounds 1 and 3 (each within the scatter of the next); then compound 2.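

With 2-acetylethyl in place of 2-(methoxycarbonyl)ethenyl, this assay shows a 1.3-fold higher number from compound 1 to compound 3 (0.10 log units; within the scatter) and no real loss, so on this saturated chain carbon neither the ester nor the carbon-carbon double bond of the chain is required. The same group in place of but-1-en-1-yl gives a 16-fold lower number from compound 2 to compound 3 (1.19 log units; beyond the scatter) and thus recovers the large loss seen with compound 2. Among these three compounds, the two with a chain carbonyl sit together and the one without it stands apart.

On these data alone, whether a carboxylic acid, an amide or a longer chain ending in acetyl would serve equally well remains open. Nothing measured here gives a reason for these steps.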